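The source may hold more compounds than are shown below. What is called first, only, known or untested is meant among the compounds shown, and "the series" means these compounds.

Of the compounds shown here, three have been measured in a functional assay on PC-3 cells (Homo sapiens) for cytotoxicity, read by MTT assay, with a stated time of 72 h; on this read-out lower numbers stand for stronger inhibition and higher numbers for weaker inhibition. For the measured compounds named here, they share a general build: a ring-bearing core joined through a chain carrying a carbonyl to a six-membered aromatic ring of carbon only that bears a fluoro group. Compound 1 `CC1=CCCC(C)(C)C1/C=C/C(=O)/C=C/c1ccccc1F` gives 4800 nM in this assay. Compound 2 `CC1=CCCC(C)(C)C1/C=C/C(=O)/C=C/c1cc(C(F)(F)F)ccc1F` differs from compound 1 only by trifluoromethyl in place of hydrogen on an aromatic carbon, and in this assay compound 2 gives 3100 nM. The step from one to the other is a 1.5-fold lower number from compound 1 to compound 2 (0.19 log units; within the scatter). Compound 3 `CC1=C(/C=C/C(=O)/C=C/c2ccc(F)cc2)C(C)(C)CCC1O` has a different core from compound 1; how the two cores differ is not broken down here. In this assay compound 3 gives 6200 nM. All three values lie within the usual scatter of one another, so no order among them can be claimed.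

Compound 4 `CC1=C(/C=C/C(=O)/C=C/c2ccc(F)c(C(F)(F)F)c2)C(C)(C)CCC1O` has not yet been measured. It is reached from compound 3 by trifluoromethyl in place of hydrogen on an aromatic carbon. Going by the values given here, this is the same kind of change as the one from compound 1 to compound 2, but not the same: in compound 2 the trifluoromethyl sits meta to a large group and para to a fluoro group, while in compound 4 it sits ortho to a fluoro group and meta to a large group. Compound 4 is expected to give about 4500 nM in this assay. The expected range for compound 4 runs from 2000 nM to 10000 nM. The step expected here is a 1.4-fold lower number from compound 3 to compound 4 (0.14 log units; within the scatter), because compound 3 gives 6200 nM in this assay and the earlier matching change gave a 1.5-fold lower number from compound 1 to compound 2 (0.19 log units; within the scatter).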

Compound 4, half-maximal inhibitory concentration: 7300 nM
The estimate for compound 4 lay 1.6-fold (0.21 log units) below the measured number; the measured number falls inside the stated range.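

In this assay, putting trifluoromethyl in place of hydrogen on an aromatic carbon gives a 1.2-fold higher number from compound 3 to compound 4 (0.07 log units; within the scatter), a step too small to tell apart from repeat-measurement noise. The same change on the other core gave a step that cannot be told apart from this one: the same change on two cores in this assay, a 1.5-fold lower number (0.19 log units; within the scatter) from compound 1 to compound 2 and a 1.2-fold higher number (0.07 log units; within the scatter) from compound 3 to compound 4, 1.8-fold (0.26 log units) apart, within the scatter of two such steps. This shows that nothing in these numbers separates the effect of the change on one core from its effect on the other, but it does not prove that the change carries over unaltered: each core offers a single pair, neither step stands clear of the scatter, and the two pairs differ in arrangement, with the trifluoromethyl of compound 4 sitting ortho to a fluoro group and meta to a large group, unlike that of compound 2.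

From the compounds shown here alone, it remains open whether trifluoromethyl placed identically on the aromatic ring of both cores would give matching steps, which would compare the cores without the added difference in position. Going by these compounds, it also remains open whether another group on that ring, such as a nitrile, an amine or a carboxylic acid, would shift the number beyond the scatter on either core.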